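Halogen swap on the aryl ketone of a chalcone

The compounds below may be only part of what the source reports. "The series", "measured", "known", "first", "only" and "open" are said of these compounds alone.

Measured compounds:
compound 1, `O=C(/C=C/c1cccc(OCc2ccccc2)c1)c1ccc(Br)cc1`: 7400 nM
compound 2, `O=C(/C=C/c1cccc(OCc2ccccc2)c1)c1cccc(Br)c1`: 7100 nM
compound 3, `O=C(/C=C/c1cccc(OCc2ccccc2)c1)c1ccc([N+](=O)[O-])cc1`: 80900 nM

In a functional assay on BT-20 cells (Homo sapiens) for cytotoxicity, read by MTT assay, with a stated time of 68 h (on this read-out higher numbers stand for weaker inhibition and lower numbers for stronger inhibition), compound 2 gives the lowest of the three numbers, yet compound 1 sits within the scatter of it, as a 1.0-fold lower number from compound 1 to compound 2 (0.02 log units; within the scatter) shows. Compound 3 lies far off: an 11-fold higher number from compound 2 to compound 3 (1.06 log units; beyond the scatter). The unmeasured compound 4, `O=C(/C=C/c1cccc(OCc2ccccc2)c1)c1ccc(Cl)cc1`, differs from compound 2 by 4-chlorophenyl in place of 3-bromophenyl on a carbonyl carbon. Among the measured compounds shown here, the step from compound 1 to compound 2 shows that moving the bromine did little, and no measured step tests chlorine against bromine. One halogen replacing another at a nearby place is expected to leave the number close to that of compound 2, so a step of a 1.1-fold higher number from compound 2 to compound 4 (0.05 log units; within the scatter) is expected. Compound 4 is therefore estimated at 8000 nM, from 4000 nM to 16000 nM.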

Compound 4, half-maximal inhibitory concentration: 63200 nM
Beside the measured number, compound 4's estimate is 7.9-fold (0.90 log units) below it; the whole stated range lies below it.
By their numbers in this assay, from the lowest: compounds 2 and 1 (each within the scatter of the next); then compounds 4 and 3 (each within the scatter of the next).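

Here the identity of the halogen matters, even though moving the bromine did not: chlorine in place of bromine on the aromatic carbon gives a large change (an 8.5-fold higher number from compound 1 to compound 4 (0.93 log units; beyond the scatter)). The comparison with the 3-bromophenyl compound points the same way (an 8.9-fold higher number from compound 2 to compound 4 (0.95 log units; beyond the scatter)). The chlorine compound instead falls level with the nitro compound (a 1.3-fold lower number from compound 3 to compound 4 (0.11 log units; within the scatter)).

Going by these compounds, whether fluoro or an amine at this place would track bromine or chlorine remains open. Nothing available explains why chlorine and bromine differ here.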